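Swapping an Acyl Cap for a Sulfonyl Cap

A few compounds are considered here, and "the series" means these few. Any claim that something is new, unique, unknown or untested is made for them only; others in the source may bear on it.

Compound 1 `CN1CCN(c2ccc(C3=NNC(c4ccc(N(C)C)cc4)C3)cc2)CC1`: 2.4%
Compound 2 `CN1CCN(c2ccc(C3=NN(C(=O)c4ccc(C(F)(F)F)cc4)C(c4ccc(N(C)C)cc4)C3)cc2)CC1`: 93.2%

Two compounds share a five-membered ring core that carries a 4-(dimethylamino)phenyl group. In a functional assay on NCI-H1975 cells (Homo sapiens) for inhibition, read by sulforhodamine B assay, tested at 10 uM (a lower number here means less inhibition, a higher number more inhibition at the concentration tested (going by the name of the read-out)), compound 1 gives 2.4%, while compound 2 gives 93.2%. Compound 2 thus stands highest of the two numbers. Going by the values given here, the single measured step runs a number 90.8 percentage points higher from compound 1 to compound 2 (beyond the scatter), so capping the ring nitrogen with an aromatic carbonyl group raised the read-out strongly.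

Compound 3 `Cc1ccc(S(=O)(=O)N2N=C(c3ccc(N4CCN(C)CC4)cc3)CC2c2ccc(N(C)C)cc2)cc1` carries a different cap: (4-methylphenyl)sulfonyl in place of (4-(trifluoromethyl)phenyl)carbonyl on an amine nitrogen in a ring. Among the compounds with values here, no measured step covers a change from one cap to another, so the only guide is that the bare nitrogen of compound 1 gave little inhibition while a capped nitrogen in compound 2 gave much. Because of a number 90.8 percentage points higher from compound 1 to compound 2 (beyond the scatter), a capped compound 3 is expected to stay near the high end, with a step of a number 13.2 percentage points lower from compound 2 to compound 3 (beyond the scatter) expected. Compound 3 is therefore estimated at 80%, in a range from 50% to 97%.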

Compound 3, a percentage reported as inhibition, at one concentration (the size of the read-out at that concentration, not a potency): 38.1%
For compound 3 the middle estimate is 41.9 percentage points above the measured one, outside the stated range (below it).
By their numbers in this assay, from the lowest: compound 1; then compound 3; then compound 2.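

The position responds to which cap it carries, not only to whether it carries one: in this assay the swap of the aromatic carbonyl cap for (4-methylphenyl)sulfonyl gives a number 55.1 percentage points lower from compound 2 to compound 3 (beyond the scatter) on an otherwise unchanged molecule. The sulfonyl cap still keeps part of the gain over the bare nitrogen, with a number 35.7 percentage points higher from compound 1 to compound 3 (beyond the scatter) for this change, so a cap alone does not guarantee the full effect. Nothing at hand explains why the two caps differ.

This swap changes both the link to the nitrogen, carbonyl to sulfonyl, and the group on the aromatic ring, trifluoromethyl to methyl, so the compounds shown cannot say which of the two matters. A (4-methylphenyl)carbonyl cap would separate them, and an acetyl cap, without any aromatic ring, remains an open case.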